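From Dimethylaminoethenyl to Phenyl on a Ring Nitrogen

A few compounds are considered here, and "the series" means these few. Any claim that something is new, unique, unknown or untested is made for them only; others in the source may bear on it.

Compound 1, `CCN1CCN(CC(=O)Nc2ccc(-c3nc(-c4ccccc4)c(-c4ccccc4)n3C)cc2)CC1`, gives 17.2% in a functional assay on HT-29 cells (Homo sapiens) for cytotoxicity, read by MTT assay, with a stated time of 24 h, tested at 6.4 ug/mL; a higher number here means a stronger effect of the compound at the concentration tested, a lower number a weaker effect.
Compound 2, `CN(C)/C=C/N1CCN(CC(=O)Nc2ccc(-c3nc(-c4ccccc4)c(-c4ccccc4)n3C)cc2)CC1`, gives 12.2% in this assay.

Of these two numbers, compound 2 stands lowest, with compound 1 nearest; the step of a number 5 percentage points lower from compound 1 to compound 2 (within the scatter) lies within the scatter. Compound 3, `Cn1c(-c2ccc(NC(=O)CN3CCN(c4ccccc4)CC3)cc2)nc(-c2ccccc2)c1-c1ccccc1`, differs from compound 2 by phenyl in place of 2-(dimethylamino)ethenyl on an amine nitrogen in a ring. Among the measured compounds shown here, no measured step exchanges a group of this kind at this position, and the single known step, a number 5 percentage points lower from compound 1 to compound 2 (within the scatter), hardly moved the read-out. No change beyond the scatter is therefore expected in this assay. Compound 3 is estimated at 15%, in a range from 3% to 32%, which means an expected step of a number 2.8 percentage points higher from compound 2 to compound 3 (within the scatter).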

Compound 3, a percentage reported as activity, at one concentration (the size of the read-out at that concentration, not a potency): 46.5%
The estimate for compound 3 lay 31.5 percentage points below the measured number, and the stated range ends below it.
By their numbers in this assay, from the lowest: compounds 2 and 1 (each within the scatter of the next); then compound 3.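

On the amine nitrogen in the ring, the choice of group matters in this assay: phenyl gives a number 34.3 percentage points higher from compound 2 to compound 3 (beyond the scatter), and against ethyl it gives a number 29.3 percentage points higher from compound 1 to compound 3 (beyond the scatter). Ethyl and 2-(dimethylamino)ethenyl stay within the scatter of each other, so among these three groups only phenyl, the one with an aromatic ring, stands apart. Nothing available explains why this change has such an effect.

Open, as far as these compounds go, is whether the effect needs the aromatic ring directly on this nitrogen, as a benzyl group would test, or whether a pyridine ring or a chlorophenyl group would keep it.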